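Methyl for Phenyl on a Ring Nitrogen: Tolerability Expected

A few compounds are considered here, and "the series" means these few. Any claim that something is new, unique, unknown or untested is made for them only; others in the source may bear on it.

Compound 1 `c1ccc(/N=N/N2CCN(c3ccccc3)CC2)cc1` was examined in an ADME assay on Vero cells (Chlorocebus sabaeus) for cytotoxicity, read by crystal violet staining; a lower number here means that less compound is tolerated, a higher number that more compound is tolerated. In this assay compound 1 is reported only as a limit, >= 100000 nM, and not as a number. This is the limit of >= 100000 nM in this assay, at which 1 of the 2 values shown sits. A second compound of related make-up, compound 2 `Fc1ccc(F)c(/N=N/Nc2ccccc2)c1`, gives 80000 nM in this assay, which is a number rather than a limit. Among the compounds with values here, no step between two measured compounds is available, since compound 1 and compound 2 differ in more than one place, and their two values show only that both are tolerated to a high degree.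

Compound 3 `CN1CCN(/N=N/c2ccccc2)CC1` differs from compound 1 in one respect: methyl in place of phenyl on an amine nitrogen in a ring. The measured compounds give no indication of the direction of such a change. Compound 3 is expected to remain tolerated much as compound 1 is, so the estimated step of a number no higher from compound 1 to compound 3 (the limit leaves the size open) is none beyond the scatter. The estimate for compound 3 is 100000 nM, within a range from 30000 nM to 300000 nM, with a fair chance that this assay again reports only a limit.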

Compound 3, half-maximal cytotoxic concentration: 45000 nM
For compound 3 the middle estimate is 2.2-fold (0.35 log units) above the measured one, and the stated range covers the measured number.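

Methyl in place of phenyl on an amine nitrogen in a ring gives the first single change that can be read in this assay, and it yields an at least 2.2-fold lower number from compound 1 to compound 3 (0.34 log units; beyond the scatter), so this ring nitrogen is a place where the choice of group shows in the read-out. Going by these compounds, compound 1 stands only as a limit, >= 100000 nM, and so the step has a lower bound while its full size stays open: the limit of >= 100000 nM in this assay, at which 1 of the 3 values shown sits. Within the data shown here, the change therefore gives a direction that the earlier compounds could not give, with less of compound 3 tolerated than of compound 1, although this rests on a single replacement.

The compounds shown leave open whether a cyclohexyl group or a longer chain such as butyl on the same ring nitrogen would stay nearer to compound 1 or nearer to compound 3, and so whether the aromatic ring itself or simply the larger group goes with the higher number. They also leave open what a benzyl group, or an amine or carboxylic acid carried on the remaining phenyl, would do in this assay.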